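Triazole Aryl Swap Among Three Compounds at the Limit

The source may hold more compounds than are shown below. What is called first, only, known or untested is meant among the compounds shown, and "the series" means these compounds.

Three compounds share one core and differ only in the group attached to an aromatic nitrogen of the triazole ring. Compound 1 `CC(=O)Nc1ccc(-n2nncc2CN2C(=O)C3(C(C#N)=C(N)Oc4c(N)cc5nc6ccccc6nc5c43)c3ccccc32)cc1` carries a 4-acetamidophenyl group. In a functional assay on A549 cells (Homo sapiens) for antiproliferative activity, read by MTT assay, with a stated time of 48 h (a lower number here means a stronger inhibitor, a higher number a weaker inhibitor), compound 1 gives > 50000 nM, which is a limit of the assay rather than a number. Compound 2 `COc1ccc(-n2nncc2CN2C(=O)C3(C(C#N)=C(N)Oc4c(N)cc5nc6ccccc6nc5c43)c3ccccc32)cc1` carries a 4-methoxyphenyl group. In this assay compound 2 gives > 50000 nM, again a limit. Compound 3 `CCc1cccc(CC)c1-n1nncc1CN1C(=O)C2(C(C#N)=C(N)Oc3c(N)cc4nc5ccccc5nc4c32)c2ccccc21` carries a 2,6-diethylphenyl group. In this assay compound 3 gives > 50000 nM, also a limit. With three limits the steps between them cannot be read: a step that the two limits leave unreadable from compound 1 to compound 2, a step that the two limits leave unreadable from compound 1 to compound 3 and a step that the two limits leave unreadable from compound 2 to compound 3 are all of unknown size because of the limit of > 50000 nM in this assay, at which 3 of the 3 values shown sit.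

Compound 4 `N#CC1=C(N)Oc2c(N)cc3nc4ccccc4nc3c2C12C(=O)N(Cc1cnnn1-c1ccc(F)c(Cl)c1)c1ccccc12` is not yet measured. It differs from compound 3 in one place: 3-chloro-4-fluorophenyl in place of 2,6-diethylphenyl on an aromatic nitrogen. Every measured step concerns this same position, and every one is unreadable, so the known compounds give no sign that changing this group moves the value out of the region where all three sit. Compound 4 is therefore expected to sit at 50000 nM, with an estimated range from 20000 nM to 100000 nM. The step this estimate implies, a number no higher from compound 3 to compound 4 (the limit leaves the size open), is expected to be none beyond the scatter.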

Compound 4, half-maximal inhibitory concentration: 43400 nM
Compound 4: middle estimate off by 1.2-fold (0.06 log units), on the high side; measured number inside the range.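

Compound 4 is the only one of these four with a measured number rather than a limit, so this position can give a readable value in this assay when the 3-chloro-4-fluorophenyl group sits on the aromatic nitrogen. Measured against the other three groups, this change gives an at least 1.1-fold lower number from compound 3 to compound 4 (0.06 log units; that floor lies within the scatter) and an at least 1.1-fold lower number from compound 2 to compound 4 (0.06 log units; that floor lies within the scatter) and an at least 1.1-fold lower number from compound 1 to compound 4 (0.06 log units; that floor lies within the scatter) with each of these steps known only as a floor. Going by these compounds, the steps among compound 1, compound 2 and compound 3 still cannot be read, and the true size of the steps to compound 4 stays open because only one end of each is a number: the limit of > 50000 nM in this assay, at which 3 of the 4 values shown sit.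

The compounds shown leave open whether the chlorine or the fluorine alone would also give a readable value, or whether both are needed. They also leave open what a phenyl ring carrying an amine or a carboxylic acid, or a longer alkyl chain in place of the phenyl ring, would do at this position, including whether any such group could bring the number far below the region where these four compounds sit.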